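Ring in place of branching on the ether chain

The source may report more compounds than this note shows. Statements on the series, on what has been measured and on what is new or still open speak of the compounds shown alone.

The measured compounds: compound 1 `CC1CCC(Oc2cccc3ccc(N)nc23)C1` with 823 nM; compound 2 `Nc1ccc2cccc(OCC3CCCC3)c2n1` with 53 nM; compound 3 `CC(C)(C)CCOc1cccc2ccc(N)nc12` with 201 nM.

In an assay on cells with melanin-concentrating hormone receptor 1 (Homo sapiens) as the target, read by radioligand binding (a lower number here means a stronger inhibitor, a higher number a weaker inhibitor), compound 3 stands second of the three, with the step of a 3.8-fold higher number from compound 2 to compound 3 (0.58 log units; beyond the scatter) setting it apart from compound 2 and the step of a 4.1-fold lower number from compound 1 to compound 3 (0.61 log units; beyond the scatter) setting it apart from compound 1. The compound still to be measured is compound 4 `Nc1ccc2cccc(OCCC3CC3)c2n1`, which differs from compound 3 by cyclopropyl in place of tert-butyl on a saturated chain carbon, two bonds along the chain from an oxygen on an aromatic ring.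

Going by the values given here, two measured steps bear on this. The step of a 3.8-fold higher number from compound 2 to compound 3 (0.58 log units; beyond the scatter) shows that a ring on the chain beside the oxygen gave a lower number than the open neopentyl branch; the step of a 16-fold lower number from compound 1 to compound 2 (1.19 log units; beyond the scatter) shows that the position of the ring within the chain matters a great deal. Compound 4 again carries a ring, though a smaller one set one bond further out. Compound 3 to compound 4 is therefore expected to give a modest step to a lower number, a 1.8-fold lower number from compound 3 to compound 4 (0.26 log units; within the scatter). Compound 4 is estimated at 110 nM, between 40 nM and 300 nM.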

Compound 4, half-maximal inhibitory concentration: 492 nM
Estimate against measurement, compound 4: 4.5-fold (0.65 log units) below; the whole stated range lies below it.
By their numbers in this assay, from the lowest: compound 2; then compound 3; then compounds 4 and 1 (each within the scatter of the next).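

In this assay a ring on the chain brought no gain in itself: tert-butyl gave way to cyclopropyl with a 2.4-fold higher number from compound 3 to compound 4 (0.39 log units; beyond the scatter) on this change, so at this place the open branch held the lower number. The change from cyclopentyl to cyclopropylmethyl on the saturated chain carbon bound to the oxygen gave the larger step, a 9.3-fold higher number from compound 2 to compound 4 (0.97 log units; beyond the scatter) here, which ties the low number of compound 2 to that group and not to rings on this chain in general. Against 3-methylcyclopentyl, the 2-cyclopropylethyl chain made no clear difference, with a 1.7-fold lower number from compound 1 to compound 4 (0.22 log units; within the scatter) for this pair.

Nothing measured here accounts for these steps. The compounds shown leave open whether cyclobutyl or cyclohexyl on the same chain carbon would match cyclopentyl, and whether an amine at the end of the chain would be tolerated.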